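Adding a methoxy group to a trimethoxy-styryl lactone

The source may hold more compounds than are shown below. What is called first, only, known or untested is meant among the compounds shown, and "the series" means these compounds.

Four compounds share a styryl-substituted six-membered oxygen heterocycle and are compared in an ADME assay on HaCaT cells (Homo sapiens) for inhibition, read by sulforhodamine B assay, with a stated time of 48 h; on this read-out higher numbers stand for weaker inhibition of growth and lower numbers for stronger inhibition of growth. Compound 1 `O=C1C=COC(/C=C/c2ccccc2)C1` gives 127 uM in this assay. Compound 2 `COc1ccc(/C=C/C2CC(=O)C=CO2)cc1` carries methoxy in place of hydrogen on an aromatic carbon and gives 145 uM in this assay; the step of a 1.1-fold higher number from compound 1 to compound 2 (0.06 log units; within the scatter) is within the usual scatter, so the two values cannot be ordered. Compound 3 `COc1cc(/C=C/C2CC=CC(=O)O2)cc(OC)c1` has a different core from compound 1, and that difference is not broken down here; compound 3 gives 8.8 uM in this assay, the lowest of the three measured numbers and beyond the scatter from both compound 1 and compound 2.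

Compound 4 `COc1cc(/C=C/C2CC=CC(=O)O2)cc(OC)c1OC` has not yet been measured. It differs from compound 3 by methoxy in place of hydrogen on an aromatic carbon. This is the same kind of change as that from compound 1 to compound 2, but the surroundings of the new group differ: in compound 4 the entering methoxy sits ortho to two methoxy groups, whereas in compound 2 it is only para to a group of 9 heavy atoms. For the measured compounds named here, the one earlier example of this change, a 1.1-fold higher number from compound 1 to compound 2 (0.06 log units; within the scatter), did not move the number beyond the scatter, so the step from compound 3 to compound 4 is expected to be small as well, about a 1.1-fold higher number from compound 3 to compound 4 (0.06 log units; within the scatter), because compound 3 gives 8.8 uM and the earlier step was within the scatter. Compound 4 is therefore estimated at 10 uM in this assay, with a plausible range from 4 uM to 25 uM.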

Compound 4, concentration for growth inhibition (reported as GI): 21.6 uM
Beside the measured number, compound 4's estimate is 2.2-fold (0.33 log units) below it, and the stated range covers the measured number.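

In this assay, methoxy in place of hydrogen on an aromatic carbon gives a 2.5-fold higher number from compound 3 to compound 4 (0.39 log units; beyond the scatter), a modest step towards weaker inhibition of growth. Set beside the earlier example of the same change, the two steps cannot be told apart, so nothing here shows that the core alters what this change does: the same change on two cores in this assay, a 1.1-fold higher number (0.06 log units; within the scatter) from compound 1 to compound 2 and a 2.5-fold higher number (0.39 log units; beyond the scatter) from compound 3 to compound 4, 2.1-fold (0.33 log units) apart, within the scatter of two such steps. For the compounds shown here, this does not show that the change behaves the same on every core, as it rests on only two pairs, and in those pairs the core is not the only thing that differs, since the entering methoxy in compound 4 is ortho to two methoxy groups and no such neighbours surround it in compound 2.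

The compounds shown leave open whether a hydroxy group, an amine or a longer chain such as ethoxy, entering on the same aromatic carbon of compound 3, would move the number as methoxy does. They also leave open how much of the low number of compound 3 belongs to its core and how much to its two methoxy groups, as no pair shown changes only one of these.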